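From compound 1 to compound 4: 1-hydroxyethyl for methyl

The source may hold more compounds than are shown below. What is called first, only, known or untested is meant among the compounds shown, and "the series" means these compounds.

In an in vitro ADME assay on microsomes (Rattus norvegicus) for metabolic stability (on this read-out lower numbers stand for a shorter-lived compound and higher numbers for a longer-lived compound), compound 1 `CC(=O)N1CCc2c(C)c3c(n2-c2ccc(C(N)=O)c(c2)N[C@@H](C)[C@H](C)C1)CC(C)(C)CC3=O` gives 0.333 h, and compound 3 `Cc1c2c(n3c1CCN(C(=O)[C@@H](N)C(C)C)C[C@@H](C)[C@H](C)Nc1cc-3ccc1C(N)=O)CC(C)(C)CC2=O` gives 0.217 h. These two numbers sit within the scatter of each other, a 1.5-fold lower number from compound 1 to compound 3 (0.19 log units; within the scatter). Compound 2 `Cc1c2c(n3c1CCN(C(=O)CN)C[C@@H](C)[C@H](C)Nc1cc-3ccc1C(N)=O)CC(C)(C)CC2=O` reads > 0.5 h, which is a limit of the assay and not a number.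

Compound 4 `Cc1c2c(n3c1CCN(C(=O)[C@H](C)O)C[C@@H](C)[C@H](C)Nc1cc-3ccc1C(N)=O)CC(C)(C)CC2=O` differs from compound 1 as follows: 1-hydroxyethyl in place of methyl on a carbonyl carbon. This places 1-hydroxyethyl in place of methyl on a carbonyl carbon. For the measured compounds named here, the closest measured changes are an at least 1.5-fold higher number from compound 1 to compound 2 (0.17 log units; that floor lies within the scatter) and a 1.5-fold lower number from compound 1 to compound 3 (0.19 log units; within the scatter), while the one larger step is an at least 2.3-fold lower number from compound 2 to compound 3 (0.36 log units; beyond the scatter). No change beyond the scatter is therefore expected in this assay. The expected step is a 1.1-fold higher number from compound 1 to compound 4 (0.02 log units; within the scatter). For compound 4 the estimated half-life is 0.35 h, with an expected range of 0.17 h to 0.7 h.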

Compound 4, half-life: 0.483 h
For compound 4 the middle estimate is 1.4-fold (0.14 log units) below the measured one, and the stated range covers the measured number.
By their numbers in this assay, from the lowest: compounds 3, 1 and 4 (each within the scatter of the next, the first and the last beyond it). At a limit, above all of these: compound 2.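

In this assay, 1-hydroxyethyl in place of methyl on a carbonyl carbon gives a 1.5-fold higher number from compound 1 to compound 4 (0.16 log units; within the scatter). Set against 1-amino-2-methylpropyl at the same place, 1-hydroxyethyl gives a 2.2-fold higher number from compound 3 to compound 4 (0.35 log units; beyond the scatter), the only step in the series beyond the scatter with a number at both ends. Set against aminomethyl at the same place, 1-hydroxyethyl gives an at least 1.0-fold lower number from compound 2 to compound 4 (0.01 log units; that floor lies within the scatter), a step with a limit at one end. Compound 2 reads > 0.5 h, which is a limit and not a number: the limit of > 0.5 h in this assay, at which 1 of the 4 values shown sits.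

Going by these compounds, what hydroxymethyl or a longer hydroxyalkyl chain on this carbonyl carbon would give in this assay stays open. So does the result for a carboxylic acid at this place.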